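From Nitro to Chloro on Compound 1

The compounds below may be only part of what the source reports. "The series", "measured", "known", "first", "only" and "open" are said of these compounds alone.

In a functional assay on KG-1a cells (Homo sapiens) for inhibition, with a stated time of 24 h (a higher number here means a weaker inhibitor, a lower number a stronger inhibitor), compound 1 (`O=[N+]([O-])c1cccc(Nc2nnc(-c3c[nH]c4ccccc34)o2)c1`) gives 25500 nM and holds the higher of the two numbers, while compound 2 (`O=[N+]([O-])c1ccc(Nc2nnc(-c3c[nH]c4ccccc34)o2)cc1`) gives 890 nM (a gap well beyond the scatter). Compound 3 (`Clc1cccc(Nc2nnc(-c3c[nH]c4ccccc34)o2)c1`) carries chloro in place of nitro on an aromatic carbon. Within the data shown here, no measured pair shows this change, so only a moderate step toward a lower number is expected in this assay for it. The expected move is a 2.8-fold lower number from compound 1 to compound 3 (0.45 log units; beyond the scatter) and remains an estimate. For compound 3 the estimate is 9000 nM (expected range 1500 nM to 40000 nM).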

Compound 3, half-maximal inhibitory concentration: 32700 nM
Compound 3: the middle estimate sits 3.6-fold (0.56 log units) below what was measured; the measured number falls inside the stated range.
By their numbers in this assay, from the lowest: compound 2; then compounds 1 and 3 (each within the scatter of the next).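

In this assay chloro in place of nitro on an aromatic carbon, meta to a large group, gives a 1.3-fold higher number from compound 1 to compound 3 (0.11 log units; within the scatter) and so leaves the number unchanged within the scatter. At this position, then, nitro is not needed to hold a number of this size, and a chloro group serves alike. No measured evidence bears on what lies behind this result. As far as these compounds go, whether an amine, a methoxy group or a carboxylic acid at this position would read the same remains open. So does whether chloro would match nitro elsewhere on the ring.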